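The source may report more compounds than this note shows. Statements on the series, on what has been measured and on what is new or still open speak of the compounds shown alone.

This account follows the step from compound 2 to compound 4 in a functional assay on PPC-1 cells (Homo sapiens) for antiproliferative activity, read by sulforhodamine B assay; a higher number here means a weaker inhibitor, a lower number a stronger inhibitor. Of the compounds shown here, three on the shared core have been measured. Compound 1, `CCCCCCCCCCCCCCCCCCNC(=O)[C@H]1CSC(CCCCCCCCCCCC)N1`, gives 13000 nM. Compound 2, `CCCCCCCCCCCCCCCCCCNC(=O)[C@H]1CSC(c2ccc(N(C)C)cc2)N1`, gives 1100 nM, the lowest of the three numbers. Compound 3, `CCCCCCCCCCCCCCCCCCNC(=O)[C@H]1CSC(c2c(Cl)cccc2Cl)N1`, gives 17100 nM. The two steps from compound 2 are both beyond the scatter: a 12-fold lower number from compound 1 to compound 2 (1.07 log units; beyond the scatter) and a 16-fold higher number from compound 2 to compound 3 (1.19 log units; beyond the scatter).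

Compound 4, `CCCCCCCCCCCCCCCCCCNC(=O)[C@H]1CSC(c2ccc(F)c(Br)c2)N1`, is not yet measured. It differs from compound 2 in one place: 3-bromo-4-fluorophenyl in place of 4-(dimethylamino)phenyl on a saturated ring carbon.

Within the data shown here, two measured steps bear on this change. Both steps away from the 4-(dimethylamino)phenyl group gave large movements, a 12-fold lower number from compound 1 to compound 2 (1.07 log units; beyond the scatter) in one direction and a 16-fold higher number from compound 2 to compound 3 (1.19 log units; beyond the scatter) in the other. The step to compound 3 also replaced this group with a halogen-bearing phenyl ring, and it gave a large rise in the number. The 3-bromo-4-fluorophenyl group of compound 4 carries its halogens at different positions of the ring than the 2,6-dichlorophenyl of compound 3, so the size of the movement is uncertain, but a rise in this assay is expected, most likely somewhat smaller than the step to compound 3.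

Compound 4 is therefore expected to give 7000 nM, within a range of 2000 nM to 25000 nM, which would correspond to an estimated step of a 6.4-fold higher number from compound 2 to compound 4 (0.80 log units; beyond the scatter).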

Compound 4, half-maximal inhibitory concentration: 4700 nM
For compound 4 the middle estimate is 1.5-fold (0.17 log units) above the measured one; the range from low to high includes it.
By their numbers in this assay, from the lowest: compound 2; then compound 4; then compounds 1 and 3 (each within the scatter of the next).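

In this assay the saturated ring carbon next to the ring nitrogen and the ring sulfur does not treat all halogen-bearing phenyl groups alike: a 3.6-fold lower number from compound 3 to compound 4 (0.56 log units; beyond the scatter) follows when 3-bromo-4-fluorophenyl replaces 2,6-dichlorophenyl, so the presence of halogens alone does not set the number. Against the alkyl group, too, the two differ: a 1.3-fold higher number from compound 1 to compound 3 (0.12 log units; within the scatter) leaves 2,6-dichlorophenyl no different from dodecyl, whereas a 2.8-fold lower number from compound 1 to compound 4 (0.44 log units; beyond the scatter) puts 3-bromo-4-fluorophenyl ahead of it. Compound 4 still does not reach compound 2, with a 4.3-fold higher number from compound 2 to compound 4 (0.63 log units; beyond the scatter) keeping 4-(dimethylamino)phenyl the best of the four groups, and nothing available here accounts for any of these differences.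

The compounds shown leave open whether the bromine, the fluorine or the two together give compound 4 its place, which a 3-bromophenyl or a 4-fluorophenyl group on the same carbon would separate. Going by these compounds, it also remains open whether the low number of compound 2 belongs to its dimethylamino group in particular, a question that an unsubstituted phenyl or a 4-methoxyphenyl group would address.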